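This account rests on a few compounds, and the source may have more. Where it says the series, first, only, none or still open, it means among the compounds named here.

Measured so far:
Compound 1 `CC(C)(C)c1[nH]cnc1/C=c1\[nH]c(=O)/c(=C/c2cccc(C(=O)c3ccccc3)c2)[nH]c1=O` gives 0.63 nM in a functional assay on BXPC-3 cells (Homo sapiens) for antiproliferative activity, read by sulforhodamine B assay, with a stated time of 72 h; a lower number here means a stronger inhibitor, a higher number a weaker inhibitor.
Compound 2 `CC(C)(C)c1[nH]cnc1/C=c1\[nH]c(=O)/c(=C/c2cccc(C(=O)c3cncs3)c2)[nH]c1=O` gives 17.1 nM in this assay.

Compound 1 stands at the lowest of the two numbers seen; its nearest neighbour, compound 2, lies well beyond the scatter above it. Compound 3 `CC(C)(C)c1[nH]cnc1/C=c1\[nH]c(=O)/c(=C/c2cccc(C(=O)c3ccoc3)c2)[nH]c1=O` differs from compound 1 in one place: furan-3-yl in place of phenyl on a carbonyl carbon. For the measured compounds named here, the one measured step that bears on this is the case in which another five-membered aromatic ring took the place of the same phenyl on the carbonyl carbon: a 27-fold higher number from compound 1 to compound 2 (1.43 log units; beyond the scatter). That step was large, so exchanging the phenyl for the furan-3-yl ring is expected to weaken inhibition in this assay as well, although a different five-membered ring need not give the same size of loss. Compound 3 is therefore estimated at 5 nM, with a likely range from 1.5 nM to 20 nM, which means an expected 7.9-fold higher number from compound 1 to compound 3 (0.90 log units; beyond the scatter).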

Compound 3, half-maximal inhibitory concentration in the BXPC-3 assay: 9.41 nM
Compound 3: middle estimate off by 1.9-fold (0.27 log units), on the low side; the range from low to high includes it.
By their numbers in the BXPC-3 assay, from the lowest: compound 1; then compounds 3 and 2 (each within the scatter of the next).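

In the BXPC-3 assay, a second five-membered aromatic ring on the carbonyl carbon also costs much of the activity of the phenyl compound, so the loss is no longer tied to the 1,3-thiazol-5-yl ring alone: a 15-fold higher number from compound 1 to compound 3 (1.17 log units; beyond the scatter). Between the two five-membered rings, the BXPC-3 assay shows no real separation, and the oxygen-containing furan-3-yl ring and the 1,3-thiazol-5-yl ring cannot be ranked: a 1.8-fold lower number from compound 2 to compound 3 (0.26 log units; within the scatter). In a physicochemical assay for solubility, read by HPLC, with a stated time of 24 h (on this read-out lower numbers stand for lower solubility and higher numbers for higher solubility), compound 1 gives a limit and not a number: < 0.1 ug/mL. In the physicochemical assay, compound 3 likewise gives a limit and not a number: < 0.1 ug/mL. In the physicochemical assay, the step between the phenyl and furan-3-yl compounds cannot be read, as neither gives a number, only a limit: the limit of < 0.1 ug/mL in the physicochemical assay, at which 2 of the 2 values shown sit.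

Going by these compounds, it remains open whether the loss follows ring size or the hetero atoms, which a pyridine ring on the same carbonyl carbon would help to separate. Also open, on these data alone, is how a saturated ring such as cyclohexyl, or a phenyl ring carrying an amine or a carboxylic acid, would fare in the BXPC-3 assay and the physicochemical assay.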